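Exchanging the Aryl Group on a Saturated Ring Carbon

The source may hold more compounds than are shown below. What is called first, only, known or untested is meant among the compounds shown, and "the series" means these compounds.

Of the compounds shown here, three sharing one core have been measured in a functional assay on Ehrlich cells (Mus musculus) for cytotoxicity, tested at 25 ug/mL; a lower number here means a weaker effect, a higher number a stronger effect of the compound at the concentration tested. Compound 1 `COc1cc(N2C(N)=C(C#N)C(c3c(O)ccc4ccccc34)C3=C2CC(C)(C)CC3=O)cc(OC)c1OC` gives 10%. Compound 2 `COc1cc(N2C(N)=C(C#N)C(c3ccc(OC)c4ccccc34)C3=C2CC(C)(C)CC3=O)cc(OC)c1OC` gives 30%, and compound 3 `COc1cc(N2C(N)=C(C#N)C(c3ccccc3Cl)C3=C2CC(C)(C)CC3=O)cc(OC)c1OC` gives 15%. Among these three numbers compound 3 stands second highest: compound 1 is nearest to it, seen in a number 5 percentage points higher from compound 1 to compound 3 (within the scatter), while compound 2 lies furthest, seen in a number 15 percentage points lower from compound 2 to compound 3 (beyond the scatter).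

Compound 4 `COc1cc(N2C(N)=C(C#N)C(c3c(OC)ccc4ccccc34)C3=C2CC(C)(C)CC3=O)cc(OC)c1OC` differs from compound 3 in a single place: 2-methoxynaphthalen-1-yl in place of 2-chlorophenyl on a saturated ring carbon. Two measured steps, a number 5 percentage points higher from compound 1 to compound 3 (within the scatter) and a number 15 percentage points lower from compound 2 to compound 3 (beyond the scatter), exchanged aryl groups on the same saturated ring carbon and so bear on this change. The entering group, 2-methoxynaphthalen-1-yl, resembles both the 2-hydroxynaphthalen-1-yl of compound 1 and the 4-methoxynaphthalen-1-yl of compound 2. Read backwards, those two steps show that placing a naphthyl group where compound 3 carries 2-chlorophenyl gave once a change within the scatter and once a modest rise. Compound 4 is therefore expected to fall between the values of compound 1 and compound 2, with an expected step of a number 5 percentage points higher from compound 3 to compound 4 (within the scatter), which may not exceed the scatter. In this assay compound 4 is estimated to give 20%, within a range from 5% to 40%.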

Compound 4, a percentage reported as activity, at one concentration (the size of the read-out at that concentration, not a potency): 5%
For compound 4 the middle estimate is 15 percentage points above the measured one; low and high end bracket the measured number.
By their numbers in this assay, from the lowest: compounds 4, 1 and 3 (each within the scatter of the next); then compound 2.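

In this assay, 2-methoxynaphthalen-1-yl in place of 2-chlorophenyl on the saturated ring carbon gives a number 10 percentage points lower from compound 3 to compound 4 (within the scatter), so entering a group with 2 six-membered aromatic rings instead of one does not by itself separate the read-out here. The two methoxy-bearing aryl groups do separate, with a number 25 percentage points lower from compound 2 to compound 4 (beyond the scatter), while methyl in place of hydrogen on the oxygen of the aromatic ring gives only a number 5 percentage points lower from compound 1 to compound 4 (within the scatter); among these compounds, then, the clear difference goes with 4-methoxynaphthalen-1-yl rather than with naphthyl groups as a whole. No measurement at hand accounts for these differences.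

The compounds shown leave open whether other groups at the 4 position of the naphthyl group, such as a hydroxyl or an amine, would also stand apart from the 2-substituted ones, or whether this pattern holds only for the methoxy group. They also leave open how a 4-methoxyphenyl group would compare on the same saturated ring carbon, and whether the differences would persist with a carboxylic acid in place of the cyano group on the shared core.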